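A few compounds are considered here, and "the series" means these few. Any claim that something is new, unique, unknown or untested is made for them only; others in the source may bear on it.

In an ADME assay on MT4 cells (Homo sapiens) for activation, read by MTT assay (a higher number here means that more compound is tolerated, a lower number that less compound is tolerated), compound 3 `CCCSc1nc(C(C)c2c(F)cccc2Cl)cc(=O)[nH]1` gives > 75000 nM and this is a limit, not a number. Compound 1 `CCCSc1nc(Cc2c(F)cccc2Cl)cc(=O)[nH]1` likewise gives only the limit > 80000 nM in this assay for its reading. Compound 2 `CCC(C)Sc1nc(Cc2c(F)cccc2Cl)c(C)c(=O)[nH]1` also gives only a limit, > 73000 nM in this assay for its reading. Among the measured compounds shown here, no compound measured so far therefore has an exact value to start from.

The next change, leading to compound 4 `CC(c1cc(=O)[nH]c(SC2CCCC2)n1)c1c(F)cccc1Cl`, puts cyclopentyl in place of propyl on a sulfur. For the measured compounds named here, the one measured step, a step that the two limits leave unreadable from compound 1 to compound 3, lies at another place in the structure and gives no size to carry over. With no readable step to draw on, no shift beyond the usual scatter is expected in this assay, and no direction can be given. That expectation rests on compound 3 and its limit > 75000 nM as the nearest reference. The expected change is an at least 1.0-fold lower number from compound 3 to compound 4 (0.02 log units; that floor lies within the scatter) as estimated here, and another limit would be no surprise. Compound 4 is estimated at 70000 nM as a central value, with 25000 nM to 110000 nM as its expected range.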

Compound 4, half-maximal cytotoxic concentration: > 71000 nM
Compound 4: a limit, no number (the forecaster's own chance of this, stated with the estimate: 70%); middle value at least 1.0-fold (0.00 log units) away from the limit.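

In this assay compound 4 gives > 71000 nM, which is a limit. Compound 3 also gives a limit, > 75000 nM. Among the compounds shown here, no step between compound 3 and compound 4 can therefore be read. The compounds shown leave open whether cyclopentyl in place of propyl on a sulfur changes the tolerated concentration at all.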